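Benzoxazole amide series: working notes toward compound 3

The compounds below may be only part of what the source reports. "The series", "measured", "known", "first", "only" and "open" are said of these compounds alone.

Compound 1 `Cc1nnsc1C(=O)Nc1nc2ccccc2o1` gives 19600 nM in an ADME assay on HEK293 cells (Homo sapiens) for cytotoxicity, read by CCK-8 assay, with a stated time of 48 h (on this read-out lower numbers stand for stronger inhibition and higher numbers for weaker inhibition), and stands as the lower of the two numbers measured. Compound 2 `O=C(Nc1nc2ccccc2o1)c1cccs1` gives 81900 nM in this assay; the step between them is a 4.2-fold higher number from compound 1 to compound 2 (0.62 log units; beyond the scatter). For the measured compounds named here, compound 3 `Cc1nnsc1C(=O)Nc1nc2c(OCc3ccccn3)cccc2o1` differs from compound 1 by (pyridin-2-yl)methoxy in place of hydrogen on an aromatic carbon, a change on the shared core rather than on the carbonyl side, so the one measured step does not bear on it. With nothing to guide the direction, no step beyond the scatter is expected in this assay. The estimate for compound 3 is 15000 nM, within 5000 nM to 50000 nM. The expected step is a 1.3-fold lower number from compound 1 to compound 3 (0.12 log units; within the scatter).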

Compound 3, half-maximal inhibitory concentration: 61800 nM
Compound 3: middle estimate off by 4.1-fold (0.61 log units), on the low side, outside the stated range (above it).
By their numbers in this assay, from the lowest: compound 1; then compounds 3 and 2 (each within the scatter of the next).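

In this assay, the core side also moves the number: (pyridin-2-yl)methoxy in place of hydrogen on this aromatic carbon gives a 3.2-fold higher number from compound 1 to compound 3 (0.50 log units; beyond the scatter), a step toward weaker inhibition. Until now, only a change on the carbonyl side had been seen to shift the read-out, so this position is not silent. Nothing measured accounts for the direction of this step.

Still open, from the compounds shown here alone, is whether a small methoxy or a benzyloxy group at this position gives a step of similar size. Also open, going by these compounds, is whether (pyridin-2-yl)methoxy has the same effect with thiophen-2-yl on the carbonyl side.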